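The source may hold more compounds than are shown below. What is called first, only, known or untested is meant among the compounds shown, and "the series" means these compounds.

In a functional assay on HCT-116 cells (Homo sapiens) for antiproliferative activity, read by MTT assay, with a stated time of 48 h (a lower number here means a stronger inhibitor, a higher number a weaker inhibitor), compound 1 `COc1cc(C(=O)/C=C/c2ccc(OCCCC(=O)NCCCCN(CCCN)CCCCN)cc2)cc(OC)c1OC` gives 29200 nM, and compound 2 `COc1ccc(/C=C/C(=O)c2cc(OC)c(OC)c(OC)c2)cc1OCCCC(=O)NCCCCN(CCCN)CCCCN` gives 73600 nM. Compound 2 therefore has the higher number of the two, which makes it the weaker inhibitor, and the gap between them lies beyond the usual scatter of repeat measurements. Compound 3 `COc1ccc(/C=C/C(=O)c2cc(OC)c(OC)c(OC)c2)cc1OCCCC(=O)NCCCCNCCCN` is compound 2 with one change: hydrogen in place of 4-aminobutyl on an amine nitrogen. Going by the values given here, no measured pair shows the effect of this change on its own, so the only guide is the span of the two numbers already in hand. A small shift towards a lower number is expected, a 1.5-fold lower number from compound 2 to compound 3 (0.17 log units; within the scatter), and it is not expected to go beyond the scatter. For compound 3, the estimated value is 50000 nM, with an expected range from 20000 nM to 120000 nM.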

Compound 3, half-maximal inhibitory concentration: 38000 nM
Beside the measured number, compound 3's estimate is 1.3-fold (0.12 log units) above it, within the range that was stated.
By their numbers in this assay, from the lowest: compounds 1, 3 and 2 (each within the scatter of the next, the first and the last beyond it).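

Read in this assay, hydrogen in place of 4-aminobutyl on this amine nitrogen gives a 1.9-fold lower number from compound 2 to compound 3 (0.29 log units; within the scatter), and this is the only comparison shown that isolates a single change at this position. The 4-aminobutyl group, with its five heavy atoms, can therefore be removed from this nitrogen without a shift that stands clear of the scatter in this assay. Compound 1 and compound 2 both carry this group on the nitrogen, so neither could show what happens without it.

No measurement shown offers an explanation for this result. On these data alone, whether a methyl or an acetyl group on this nitrogen would read the same stays open, as does whether removing 4-aminobutyl from compound 1 would give a similar step.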